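Notes on the step from compound 2 to compound 3

A few compounds are considered here, and "the series" means these few. Any claim that something is new, unique, unknown or untested is made for them only; others in the source may bear on it.

Among the measured compounds shown here, compound 2 `Cc1cnn(C(=O)N2CCCCC2)c1` is the only member of the series with a number in an assay on membranes from brain for binding affinity to Monoacylglycerol lipase ABHD6 (Mus musculus), read by fluorescence, with stated times of 1 h and 30 min; a higher number here means a weaker inhibitor, a lower number a stronger inhibitor; in it compound 2 gives 1100 nM. Compound 1 `Cc1cnn(C(=O)NCc2ccc(OCc3ccccc3)cc2)c1` belongs to the same series but carries no result in this assay, since for compound 1 the entry stands as "not determined" (no result reported), so nothing can be set against compound 2 from that side. Compound 3 `O=C(N1CCCCC1)n1cccn1` is not yet measured. The change from compound 2 to compound 3 is hydrogen in place of methyl on an aromatic carbon. For the measured compounds named here, no measured pair shows what such a change does, so the expectation rests on the single number for compound 2 alone. The change removes one heavy atom only, and the expected step from compound 2 to compound 3 is a 1.5-fold higher number from compound 2 to compound 3 (0.16 log units; within the scatter), toward a somewhat weaker inhibitor, of a size that may well stay within the usual scatter. Compound 3 is estimated at 1600 nM, with a range from 500 nM to 5000 nM.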

Compound 3, half-maximal inhibitory concentration: 5000 nM
The estimate for compound 3 lay 3.1-fold (0.49 log units) below the measured number; the range from low to high includes it.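

In this assay the series now has its first measured pair, and it shows that this position on the aromatic carbon is not indifferent to a small change: hydrogen in place of methyl gives a 4.5-fold higher number from compound 2 to compound 3 (0.66 log units; beyond the scatter). A single carbon, with no ring, donor, acceptor or charge involved, is enough to shift the number beyond the scatter, and the shift goes toward a weaker inhibitor. Nothing at hand accounts for the size of this step.

On these data alone, whether a longer chain such as ethyl, or a chlorine atom, on the same aromatic carbon would carry the trend further or reverse it remains open. Also open, as far as these compounds go, is whether the methyl has the same effect when the group on the other ring atom is different, since this rests on one pair.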